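Sulfamate series: amine variation on the benzoyl ring

The source may hold more compounds than are shown below. What is called first, only, known or untested is meant among the compounds shown, and "the series" means these compounds.

Compound 2 `CCCN(CCC)c1cccc(C(=O)N2CCc3ccc(OS(N)(=O)=O)cc3C2)c1` stands lowest of the two values at hand: in an assay on HEK293 cells for inhibition of Steryl-sulfatase (Homo sapiens), tested at 1 uM (on this read-out lower numbers stand for a weaker effect and higher numbers for a stronger effect at the one concentration tested), compound 2 gives 54.8%. Compound 1 `CCN(Cc1ccc(Br)cc1)c1ccc(C(=O)N2CCc3ccc(OS(N)(=O)=O)cc3C2)cc1` gives 95.9% in this assay, a value that lies beyond the scatter above compound 2. Compound 1 and compound 2 differ in more than one place, so their two values show only that variation on the amine-bearing benzoyl part of the shared core can move the read-out far.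

Compound 3 `CCN(Cc1cccnc1)c1cccc(C(=O)N2CCc3ccc(OS(N)(=O)=O)cc3C2)c1` is not yet measured. It differs from compound 2 in one place: ethyl((pyridin-3-yl)methyl)amino in place of dipropylamino on an aromatic carbon. No single-step comparison between measured compounds exists for this change. Compound 1 gives 95.9%, which points upward. An upward step is therefore expected, a number 23.2 percentage points higher from compound 2 to compound 3 (beyond the scatter), beyond the scatter. Compound 3 is estimated at 78%, with a range from 58% to 94%.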

Compound 3, a percentage reported as inhibition, at one concentration (the size of the read-out at that concentration, not a potency): 33.5%
The estimate for compound 3 lay 44.5 percentage points above the measured number, outside the stated range (below it).
By their numbers in this assay, from the lowest: compound 3; then compound 2; then compound 1.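

Ethyl((pyridin-3-yl)methyl)amino in place of dipropylamino, on an aromatic carbon meta to a large group, gives a number 21.3 percentage points lower from compound 2 to compound 3 (beyond the scatter) and is the first single-place step in the series. At this position, then, the entering group, with its six-membered aromatic ring and added hydrogen-bond acceptor, lowers the read-out rather than raising it, and compound 1, which differs from compound 3 in more than one place, cannot be used to predict this change. Nothing at hand explains the drop.

Still open, as far as these compounds go, is whether the ring nitrogen matters, since a plain benzyl group on the same ethylamino nitrogen at this place would separate the ring from that nitrogen. Also open, from the compounds shown here alone, is how a shorter dialkylamine such as diethylamino would compare with dipropylamino here.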